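The source may report more compounds than this note shows. Statements on the series, on what has been measured and on what is new or still open speak of the compounds shown alone.

Measured so far:
- compound 1, `Cc1cccc(Cn2c(CN3CCN(C(=O)c4cccnc4)CC3)nc3ccccc32)c1`: 24.5%
- compound 2, `CC(=O)N1CCN(Cc2nc3ccccc3n2Cc2cccc(C)c2)CC1`: 70.3%

Going by the values given here, in an assay on isolated protein for inhibition of aldehyde dehydrogenase 1A1 (Homo sapiens), read by spectrophotometry, tested at 10 uM (on this read-out higher numbers stand for more inhibition at the one concentration tested (going by the name of the read-out) and lower numbers for less inhibition), compound 2 stands highest of the two numbers measured so far; the only other compound, compound 1, gives 24.5%, and the one recorded step, a number 45.8 percentage points higher from compound 1 to compound 2 (beyond the scatter), lies well beyond the usual scatter.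

The next compound, compound 3, `Cc1cccc(Cn2c(CN3CCN(C(=O)c4ccncc4)CC3)nc3ccccc32)c1`, differs from compound 2 in a single place: pyridin-4-yl in place of methyl on a carbonyl carbon

Among the compounds with values here, only one measured step bears on this change, and it runs the other way: a number 45.8 percentage points higher from compound 1 to compound 2 (beyond the scatter) accompanied the swap of a pyridin-3-yl for a methyl on the same carbonyl carbon. Compound 3 now puts an aromatic six-membered ring with one nitrogen back onto that carbonyl carbon, this time as pyridin-4-yl. Within the data shown here, whether the different point of attachment on the ring matters cannot be judged from these two compounds alone; the nearest precedent is the large rise seen in this assay on going from compound 1 to compound 2.

A large fall is therefore expected, a number 40.3 percentage points lower from compound 2 to compound 3 (beyond the scatter), because compound 1 with its pyridin-3-yl gave 24.5%. Compound 3 is estimated at 30%, in a range from 10% to 55%.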

Compound 3, a percentage reported as inhibition, at one concentration (the size of the read-out at that concentration, not a potency): 20.6%
Estimate against measurement, compound 3: 9.4 percentage points above; the measured number falls inside the stated range.
By their numbers in this assay, from the lowest: compounds 3 and 1 (each within the scatter of the next); then compound 2.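

With a second ring on this carbonyl carbon, the low number of compound 1 no longer stands alone: in this assay, putting pyridin-4-yl in place of methyl gives a number 49.7 percentage points lower from compound 2 to compound 3 (beyond the scatter), a large step in the same sense as the contrast already seen between methyl and pyridin-3-yl. The point of attachment on the ring cannot be told apart in these data, since the change from pyridin-3-yl to pyridin-4-yl gives a number 3.9 percentage points lower from compound 1 to compound 3 (within the scatter), so among these three compounds the acetyl group of compound 2 stands alone at the high end, while both pyridinyl carbonyl groups sit together at the low end. Nothing measured here says why the methyl and the two ring groups differ so much on this carbonyl carbon.

The compounds shown cannot separate the effect of having a ring at all from that of the ring nitrogen, a question that a plain phenyl on the same carbonyl carbon would address. They also leave open how far the high number holds as the methyl grows, for instance to an ethyl or a cyclopropyl, which would fill the wide gap between a single carbon and a whole aromatic ring.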